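Methoxy in place of hydroxy on the shared core

A few compounds are considered here, and "the series" means these few. Any claim that something is new, unique, unknown or untested is made for them only; others in the source may bear on it.

Compound 1, `O=C(Nc1cccc(-n2cc(-c3ccncc3)c(-c3cc(O)cc(Cl)c3)n2)c1)Nc1ccc(Cl)c(C(F)(F)F)c1`, gives 95% in a functional assay on Hs-578T cells (Homo sapiens) for inhibition, read by sulforhodamine B assay, with a stated time of 48 h, tested at 0.01 uM; on this read-out lower numbers stand for a stronger effect and higher numbers for a weaker effect at the one concentration tested. Of the two numbers available it stands lowest; the nearest is compound 2, `O=C(Nc1cccc(-n2cc(-c3ccncc3)c(-c3cc(O)cc(Cl)c3)n2)c1)Nc1ccc(Cl)c(Cl)c1`, which in this assay gives 98%. Within the data shown here, the single measured step, a number 3 percentage points higher from compound 1 to compound 2 (within the scatter), concerns the exchange of trifluoromethyl against chloro on the urea-bearing aryl and stayed within the scatter.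

Compound 3, `COc1cc(Cl)cc(-c2nn(-c3cccc(NC(=O)Nc4ccc(Cl)c(C(F)(F)F)c4)c3)cc2-c2ccncc2)c1`, differs from compound 1 by methyl in place of hydrogen on an oxygen on an aromatic ring, so that the hydroxy becomes a methoxy and the 3-chloro-5-hydroxyphenyl becomes a 3-chloro-5-methoxyphenyl. Among the measured compounds shown here, no measured step touches this oxygen; the step of a number 3 percentage points higher from compound 1 to compound 2 (within the scatter) lies on the other end of the molecule and offers no guidance on the direction. Both measured values already sit near the top of the scale at this concentration, which leaves little room for a higher number, and nothing in the data argues for a lower one. For compound 3 the expected step is therefore a number 1 percentage points higher from compound 1 to compound 3 (within the scatter), not beyond the scatter. Compound 3 is estimated at 96%, within a range from 86% to 100%.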

Compound 3, a percentage reported as activity, at one concentration (the size of the read-out at that concentration, not a potency): 95%
Compound 3: the middle estimate sits 1 percentage points above what was measured; the measured number falls inside the stated range.
By their numbers in this assay, from the lowest: compounds 1, 3 and 2 (each within the scatter of the next).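

Methyl in place of hydrogen on the oxygen gives, in this assay, no change at the digits printed from compound 1 to compound 3 (within the scatter), and this is the only measured step at this oxygen, since the earlier pair differed only at the far end of the molecule. At this one concentration the read-out therefore does not separate hydroxy from methoxy on the core of compound 1, so the hydrogen on this oxygen makes no difference that can be read here, with the 3-chloro-5-substituted phenyl otherwise unchanged. Nothing available bears on why this exchange leaves the number where it is.

Still open, on these data alone, is whether a different group at this place on the aromatic ring, such as an amine, a carboxylic acid or a longer chain like ethoxy, would give a step beyond the scatter. Also open, as far as these compounds go, is whether the same exchange of hydroxy for methoxy would read the same with the chloro substituent of compound 2 at the other end, and whether hydroxy and methoxy would still match at a higher concentration in this cell line.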